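Extending the acyl group of compound 3

The compounds below may be only part of what the source reports. "The series", "measured", "known", "first", "only" and "open" are said of these compounds alone.

Compound 1 `COc1cccc(CCCNC(C)=O)c1` gives 63 nM in an assay for binding affinity to melatonin receptor (Gallus gallus); a lower number here means a stronger inhibitor, a higher number a weaker inhibitor. Compound 2 `CCCCC(=O)NCCCCc1ccccc1OC` gives 9190 nM in this assay, and compound 3 `CC(=O)NCCCc1cccc(F)c1` gives 1920 nM. Among the measured compounds shown here, compound 3 therefore stands second highest of the three numbers, between compound 2 and compound 1; the single measured step with one change, a 30-fold higher number from compound 1 to compound 3 (1.48 log units; beyond the scatter), is large. Compound 4 `CCCC(=O)NCCCc1cccc(F)c1` differs from compound 3 by ethyl in place of hydrogen on a saturated chain carbon bound to a carbonyl carbon. For the measured compounds named here, no measured pair bears on this change directly: the step from compound 1 to compound 3 concerns the aromatic substituent, and compound 2 carries a longer acyl group together with a different chain and a methoxy group. Compound 4 is therefore expected to show only a modest step, a 2.7-fold lower number from compound 3 to compound 4 (0.44 log units; beyond the scatter), toward a lower number. Compound 4 is estimated at 700 nM, within 150 nM to 3500 nM.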

Compound 4, inhibition constant: 434 nM
The estimate for compound 4 lay 1.6-fold (0.21 log units) above the measured number; measured number inside the range.
By their numbers in this assay, from the lowest: compound 1; then compound 4; then compound 3; then compound 2.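

In this assay there is now a measured step at the acyl end of the molecule, a 4.4-fold lower number from compound 3 to compound 4 (0.65 log units; beyond the scatter), and it shows that ethyl in place of hydrogen on a saturated chain carbon bound to a carbonyl carbon lowers the number rather than raising it. The earlier single-change step spoke only to the aromatic substituent. Nothing available accounts for this step.

From the compounds shown here alone, whether a longer chain or a phenyl group at this carbon would lower the number further stays open. So does whether the same change would carry over to the methoxy-bearing compound 1.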